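Swapping a chain for a ring at high protein binding

This account rests on a few compounds, and the source may have more. Where it says the series, first, only, none or still open, it means among the compounds named here.

In an ADME assay on a cell-free system (plasma, Rattus norvegicus) for protein binding, compound 1 `CO[C@H](C)c1c(NC(=O)Nc2cnc(-n3nccn3)c(Cl)c2)cnc2cc(Cl)nn12` gives 96.8% and compound 2 `CO[C@@H](C)c1c(NC(=O)Nc2cnc(-n3nccn3)c(Cl)c2)cnc2cc(Cl)nn12` gives 97%. Compound 2 therefore stands level with compound 1, with nearly all of it bound to plasma protein. Within the data shown here, the one measured step, a 1.1-fold lower unbound fraction from compound 1 to compound 2 (0.03 log units; within the scatter), comes with the fact that compounds 1 and 2 differ only in the configuration as drawn.

Compound 3 `O=C(Nc1cnc(-n2nccn2)c(Cl)c1)Nc1cnc2cc(Cl)nn2c1C1CCOCC1` brings a larger change: oxan-4-yl in place of 1-methoxyethyl on an aromatic carbon. The measured step bears on this only loosely, since it swaps no group and says nothing about a ring taking the place of a chain. Among the measured compounds shown here, with no measured step pointing either way, no clear shift in this assay is expected. The expected step is a 1.2-fold higher unbound fraction from compound 2 to compound 3 (0.07 log units; within the scatter), which stays inside the usual scatter. For compound 3 the estimate is 96.5%, with an expected range from 93% to 98.5%.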

Compound 3, plasma protein binding: 97.7%
The estimate for compound 3 lay 1.5-fold (0.18 log units) (unbound fraction) above the measured number; measured number inside the range.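

The steps a 1.3-fold lower unbound fraction from compound 2 to compound 3 (0.12 log units; within the scatter) and a 1.4-fold lower unbound fraction from compound 1 to compound 3 (0.14 log units; within the scatter) show that in this assay a ring can take the place of the chain on this aromatic carbon while the read-out stays level. Oxan-4-yl brings one six-membered non-aromatic ring and loses the defined stereocentre, yet compound 3 still has nearly all of its material bound to plasma protein. The reading holds from both starting compounds, which form a closely matched pair: the fact that compounds 1 and 2 differ only in the configuration as drawn.

Going by these compounds, all three compounds carry a neutral, oxygen-containing group at this place, so whether an amine or a carboxylic acid there would leave more of the compound free remains open. Also open, on these data alone, is whether the same swap would stay level on a different core with much weaker protein binding.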